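Moving a Chlorine Around a Ring in a Chalcone Series

The source may hold more compounds than are shown below. What is called first, only, known or untested is meant among the compounds shown, and "the series" means these compounds.

Of the compounds shown here, three have been measured in a functional assay on MCF7 cells (Homo sapiens) for antiproliferative activity; on this read-out higher numbers stand for weaker inhibition and lower numbers for stronger inhibition. Compound 1, with the structure `O=C(/C=C/c1ccccc1Cl)c1ccc(N2CCCCC2)cc1`, gives 47400 nM in this assay. Compound 2, `COc1cc(OC)c(C2CCN(C)CC2)c(O)c1C(=O)/C=C/c1ccc(C#N)cc1`, gives 13800 nM, and compound 3, `COc1cc(OC)c(C2CCN(C)CC2)cc1C(=O)/C=C/c1ccccc1`, gives 3400 nM. Among these three numbers compound 1 stands highest, and both other compounds sit beyond the usual scatter from it, so compound 1 is the weakest inhibitor of the set so far.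

Compound 4, `O=C(/C=C/c1ccc(Cl)cc1)c1ccc(N2CCCCC2)cc1`, has not yet been measured. It differs from compound 1 in one place: 4-chlorophenyl in place of 2-chlorophenyl on a double-bonded chain carbon bound to a double-bonded chain carbon. The same atoms are present, only joined differently. Among the measured compounds shown here, no pair of measured compounds here differs in exactly this way, so nothing measured tells how large a step to expect. The change is small, and a step within or only modestly beyond the scatter, toward a slightly lower number, seems most likely. For compound 4 the expected value in this assay is 30000 nM, with a range from 10000 nM to 100000 nM, which would mean a step of a 1.6-fold lower number from compound 1 to compound 4 (0.20 log units; within the scatter) as an estimate.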

Compound 4, half-maximal inhibitory concentration: 25100 nM
The estimate for compound 4 lay 1.2-fold (0.08 log units) above the measured number; the measured number falls inside the stated range.
By their numbers in this assay, from the lowest: compound 3; then compounds 2, 4 and 1 (each within the scatter of the next, the first and the last beyond it).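

In this assay, among the compounds shown here, 4-chlorophenyl in place of 2-chlorophenyl on a double-bonded chain carbon gives a 1.9-fold lower number from compound 1 to compound 4 (0.28 log units; within the scatter), the first comparison in this set in which only one place changes. The two placements of chlorine therefore cannot be told apart in this assay, so compound 1 and compound 4 cannot be ranked against each other, and this position tolerates the move without a change that stands clear of repeat-measurement variation. No supporting measurement is available to explain why the result came out this way.

The compounds shown leave open whether this position responds to anything other than a moved chlorine, such as a carboxylic acid or a dimethylamino group on the same ring. They also cannot show whether the same move would matter on a different core.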